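The source may hold more compounds than are shown below. What is called first, only, known or untested is meant among the compounds shown, and "the series" means these compounds.

Three compounds share one core and differ only in the chain that hangs from an oxygen on a saturated carbon. Compound 1 `CC(=O)OCCC(=O)O[C@H](CC=C(C)C)C1=CC(=O)c2c(O)ccc(O)c2C1=O` gives 17300 nM in a functional assay on HeLa cells (Homo sapiens) for cytotoxicity, read by MTT assay (on this read-out lower numbers stand for stronger inhibition and higher numbers for weaker inhibition), compound 2 `CCC(C)(O)CC(=O)O[C@H](CC=C(C)C)C1=CC(=O)c2c(O)ccc(O)c2C1=O` gives 25200 nM, and compound 3 `COCCO[C@H](CC=C(C)C)C1=CC(=O)c2c(O)ccc(O)c2C1=O` gives 62400 nM, the highest of the three numbers, lying a 2.5-fold higher number from compound 2 to compound 3 (0.39 log units; beyond the scatter) and a 3.6-fold higher number from compound 1 to compound 3 (0.56 log units; beyond the scatter). Compound 4 `CC(=O)OC(C)CO[C@H](CC=C(C)C)C1=CC(=O)c2c(O)ccc(O)c2C1=O` differs from compound 3 by 1-acetoxyethyl in place of methoxymethyl on a saturated chain carbon bound to an oxygen on a saturated carbon. Both steps leading to compound 3 were modest rises when a chain bearing a carbonyl gave way to 2-methoxyethyl, so for compound 4 the returning acetoxy group is expected to pull the number back down by a similarly modest amount, a 2.1-fold lower number from compound 3 to compound 4 (0.32 log units; beyond the scatter). Compound 4 is thus estimated at 30000 nM, within a range from 12000 nM to 75000 nM.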

Compound 4, half-maximal inhibitory concentration: 40100 nM
Beside the measured number, compound 4's estimate is 1.3-fold (0.13 log units) below it, within the range that was stated.
By their numbers in this assay, from the lowest: compounds 1, 2, 4 and 3 (each within the scatter of the next, the first and the last beyond it).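

In this assay, 1-acetoxyethyl in place of methoxymethyl on this saturated chain carbon gives a step within the scatter (a 1.6-fold lower number from compound 3 to compound 4 (0.19 log units; within the scatter)), so the added acetoxy group brings no clear change. Both compound 1 and compound 4 carry an acetoxy group, yet the step between them lies beyond the scatter (a 2.3-fold higher number from compound 1 to compound 4 (0.37 log units; beyond the scatter)), while the step from the hydroxy-bearing carbonyl chain does not (a 1.6-fold higher number from compound 2 to compound 4 (0.20 log units; within the scatter)). As far as these compounds go, whether an amine or a carboxylic acid on this chain would move the number beyond the scatter stays open. No available measurement explains these differences.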